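The compounds below may be only part of what the source reports. "The series", "measured", "known", "first", "only" and "open" are said of these compounds alone.

Compound 1, `CC(C)c1nc(Nc2cccc3c2CC(O)CC3)oc1-c1ccc(C(F)(F)F)cc1`: 114 nM in an in vitro functional assay on cells for antagonist activity at transient receptor potential cation channel subfamily V member 1 (Homo sapiens), read by FLIPR and calcium flux; on this read-out higher numbers stand for weaker inhibition and lower numbers for stronger inhibition.
Compound 2, `OC1CCc2cccc(Nc3nc(Br)c(-c4ccc(C(F)(F)F)cc4)o3)c2C1`: 9 nM in this assay.

Compound 2 holds the lowest of the two numbers in this assay; its nearest neighbour is compound 1, reached by a single change, a 13-fold lower number from compound 1 to compound 2 (1.10 log units; beyond the scatter). Compound 3, `N#Cc1ccc(-c2nc(Nc3cccc4c3CC(O)CC4)oc2-c2ccc(C(F)(F)F)cc2)cc1`, carries 4-cyanophenyl in place of bromo on an aromatic carbon. For the measured compounds named here, the only measured step acts at this same position, where a 13-fold lower number from compound 1 to compound 2 (1.10 log units; beyond the scatter) was large, but it swapped one small group for another; no measured step shows a small group giving way to a ring. The expected step is a 3.3-fold higher number from compound 2 to compound 3 (0.52 log units; beyond the scatter), a modest weakening. Compound 3 is therefore estimated at 30 nM, within 6 nM to 150 nM.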

Compound 3, half-maximal inhibitory concentration: 2 nM
Estimate against measurement, compound 3: 15-fold (1.18 log units) above; measured number below the stated range.
By their numbers in this assay, from the lowest: compound 3; then compound 2; then compound 1.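

At this position on the shared core, a ring is tolerated as well as a small group: 4-cyanophenyl in place of bromo gives a 4.5-fold lower number from compound 2 to compound 3 (0.65 log units; beyond the scatter) in this assay, and in place of isopropyl it gives a 57-fold lower number from compound 1 to compound 3 (1.76 log units; beyond the scatter) as the larger step. Among these three compounds, the largest group carries the lowest number, although three compounds cannot establish a trend. Nothing measured here explains this gain. From the compounds shown here alone, it remains open whether the nitrile or the phenyl ring accounts for the gain, and how a plain phenyl, a morpholine or a carboxylic acid would behave at this position.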